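The source may hold more compounds than are shown below. What is called first, only, known or untested is meant among the compounds shown, and "the series" means these compounds.

Measured in a functional assay on the whole organism for antagonist activity, with Mus musculus as the target; on this read-out higher numbers stand for an effect only at larger amounts of compound and lower numbers for an effect already at smaller amounts:
- Compound 1 `CSc1nnc(-c2ccccc2Cl)n1C`: > 50 mg/kg
- Compound 2 `CSc1nnc(-c2ccccc2F)n1C`: 8.8 mg/kg

The value of compound 1 is a limit of the assay. Among the measured compounds shown here, compound 2 therefore holds the only actual number. Compound 3 `Cn1c(-c2ccccc2F)nnc1S(C)(=O)=O` carries methylsulfonyl in place of methylsulfanyl on an aromatic carbon. For the measured compounds named here, no measured step covers this change. Going by the values given here, the only step, an at least 5.6-fold lower number from compound 1 to compound 2 (0.75 log units; beyond the scatter), is a fluoro in place of chloro at a different place, and it bears only on the width of the range: one exchange can move this assay well beyond the scatter. A small rise is expected, with low confidence, as a 1.7-fold higher number from compound 2 to compound 3 (0.23 log units; within the scatter). Compound 3 is estimated at 15 mg/kg (range 3 mg/kg to 60 mg/kg).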

Compound 3, dose for half-maximal effect: 17.6 mg/kg
The estimate for compound 3 lay 1.2-fold (0.07 log units) below the measured number; the measured number falls inside the stated range.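

At the aromatic carbon between two ring nitrogen atoms, methylsulfonyl in place of methylsulfanyl gives in this assay a 2.0-fold higher number from compound 2 to compound 3 (0.30 log units; within the scatter), so the two groups cannot be told apart at this position. Among the compounds shown here, the earlier compounds showed only a halogen exchange elsewhere, so this is the first reading here, and it shows that this position accepts both sulfur groups. Nothing available bears on a cause for this result.

Going by these compounds, whether an amine, a methoxy group or a longer chain would be accepted at this position stays open. Also open, on these data alone, is how methylsulfonyl reads with chloro in place of fluoro.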